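Nitro to dimethylamino: what compound 4 may tolerate

A few compounds are considered here, and "the series" means these few. Any claim that something is new, unique, unknown or untested is made for them only; others in the source may bear on it.

Measured so far in an ADME assay on J774.A1 cells (Mus musculus) for cytotoxicity, read by MTT assay, with a stated time of 48 h; a lower number here means that less compound is tolerated, a higher number that more compound is tolerated:
compound 1, `COc1ccc(/C=C/C(=O)/C(C)=C/c2ccc([N+](=O)[O-])cc2)cc1`, gives 36600 nM
compound 2, `C/C(=C\c1ccc([N+](=O)[O-])cc1)C(=O)/C=C/c1ccc([N+](=O)[O-])cc1`, gives 43000 nM
compound 3, `C/C(=C\c1ccc([N+](=O)[O-])cc1)C(=O)/C=C/c1ccc(N(C)C)cc1`, gives 24700 nM

All three numbers sit within the usual scatter of one another, so none of the three can be called better or worse tolerated than the others. Compound 2 and compound 3 differ in one place: dimethylamino in place of nitro on an aromatic carbon. In this assay that change gave a 1.7-fold lower number from compound 2 to compound 3 (0.24 log units; within the scatter). Compound 1 and compound 2 differ in their cores: methoxy in place of nitro on an aromatic carbon. That difference gave a 1.2-fold higher number from compound 1 to compound 2 (0.07 log units; within the scatter), and between compound 1 and compound 3 the step is a 1.5-fold lower number from compound 1 to compound 3 (0.17 log units; within the scatter), again within the scatter.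

Compound 4, `COc1ccc(/C=C/C(=O)/C(C)=C/c2ccc(N(C)C)cc2)cc1`, has not yet been measured in this assay. It differs from compound 1 by dimethylamino in place of nitro on an aromatic carbon. The place of the change is described in the same words as for the pair of compound 2 and compound 3, so this is the same change made on the core of compound 1. Among the compounds with values here, the step is expected to be a 1.7-fold lower number from compound 1 to compound 4 (0.22 log units; within the scatter), resting on the earlier step of a 1.7-fold lower number from compound 2 to compound 3 (0.24 log units; within the scatter) and on the fact that no step among the three measured compounds went beyond the scatter. Compound 4 is therefore estimated to give 22000 nM, with a likely range from 11000 nM to 44000 nM.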

Compound 4, half-maximal cytotoxic concentration: 34300 nM
For compound 4 the middle estimate is 1.6-fold (0.19 log units) below the measured one, within the range that was stated.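

In this assay, putting dimethylamino in place of nitro on the core of compound 1 gave a 1.1-fold lower number from compound 1 to compound 4 (0.03 log units; within the scatter). Set beside the same change on the other core, the two steps cannot be told apart: the same change on two cores in this assay, a 1.7-fold lower number (0.24 log units; within the scatter) from compound 2 to compound 3 and a 1.1-fold lower number (0.03 log units; within the scatter) from compound 1 to compound 4, 1.6-fold (0.21 log units) apart, within the scatter of two such steps This shows that on these two cores the swap gave no step beyond the scatter and that the core made no difference that can be read, but it does not show that the change has any real effect, and it gives no estimate of how large that effect might be; two small steps are also a weak test of carrying a change across cores, since a shift that really depended on the core could stay hidden in the scatter, and two pairs say nothing about cores outside this series.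

The compounds shown leave open whether a different group on that aromatic carbon, such as a carboxylic acid or a primary amine, would move the number beyond the scatter on either core. They also leave open whether the same swap would stay this small in other cell types or over a different exposure time.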